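The source may report more compounds than this note shows. Statements on the series, on what has been measured and on what is new or still open speak of the compounds shown alone.

- Compound 1 `CC1(Cc2ccccc2)CC(S(=O)(=O)c2ccc(F)cc2)=C(c2ccc(/C(N)=N/O)cc2)O1`: 102000 nM
- Compound 2 `N/C(=N\O)c1ccc(C2=C(S(=O)(=O)c3ccc(F)cc3)CC3(CCCCC3)O2)cc1`: 92900 nM
- Compound 3 `COc1ccc(CC2(C)CC(S(=O)(=O)c3ccc(F)cc3)=C(c3ccc(/C(N)=N/O)cc3)O2)cc1`: > 100000 nM (a limit)

All three results come from an ADME assay on cells (Peritoneal macrophage, Mus musculus, strain Balb/c) for cytotoxicity, read by resazurin assay, with a stated time of 72 h; on this read-out lower numbers stand for higher toxicity in this test and higher numbers for lower toxicity in this test. Compound 3 stands at a limit of this test, not at a number: the limit of > 100000 nM in this assay, at which 1 of the 3 values shown sits.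

Compound 4 `CC1(Cc2cccc(CO)c2)CC(S(=O)(=O)c2ccc(F)cc2)=C(c2ccc(/C(N)=N/O)cc2)O1` has the same atoms as compound 3, joined differently: 3-(hydroxymethyl)phenyl in place of 4-methoxyphenyl on a saturated chain carbon bound to a saturated ring carbon. Here 3-(hydroxymethyl)phenyl takes the place of 4-methoxyphenyl, on a saturated chain carbon bound to a saturated ring carbon. Among the measured compounds shown here, the one measured step in this group, a step that the limit leaves unreadable from compound 1 to compound 3, has no readable size and so suggests no direction. The readable values, compound 1 with 102000 nM and compound 2 with 92900 nM, lie close together. The expected a number no higher from compound 3 to compound 4 (the limit leaves the size open) therefore stays within the usual scatter, with no direction favoured. For compound 4 the estimated value is 100000 nM, with an expected range of 55000 nM to 180000 nM.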

Compound 4, half-maximal cytotoxic concentration: > 100000 nM
Compound 4 gave a limit, no number; the forecaster's own chance of this, stated with the estimate: 50%; the middle value sits exactly at the limit.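

Among the compounds shown here, compound 4 gives a limit rather than a number, so no step from compound 1 or compound 3 to compound 4 can be read: the limit of > 100000 nM in this assay, at which 2 of the 4 values shown sit. From the compounds shown here alone, whether 3-(hydroxymethyl)phenyl in place of 4-methoxyphenyl changes the result in this assay stays open.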